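The source may hold more compounds than are shown below. What is called first, only, known or untested is meant among the compounds shown, and "the series" means these compounds.

Compound 1 `Cc1c(C)c2c(c(C)c1N)CC(C)(CNCCCCc1ccccc1)O2` gives 80 nM 
Compound 2 `CCCc1ccc(C2c3c(C)c(N)c(C)c(C)c3OC2(C)C)cc1` gives 290 nM 

In a functional assay (microsomes, liver) with Rattus norvegicus as the target (on this read-out lower numbers stand for stronger inhibition and higher numbers for weaker inhibition), compound 2 stands at the higher of the two numbers (290 nM) and compound 1 gives 80 nM, a gap beyond the scatter, which makes compound 2 the weaker inhibitor of the pair. Compound 3 `CCCCCc1ccc(C2c3c(C)c(N)c(C)c(C)c3OC2(C)C)cc1` differs from compound 2 in one place (ethyl in place of hydrogen on a saturated chain carbon, three bonds along the chain from an aromatic carbon): ethyl in place of hydrogen on a saturated chain carbon, three bonds along the chain from an aromatic carbon, which turns propyl to pentyl. Within the data shown here, no measured pair shows what this change does in this assay, so only a slight move towards a lower number is expected, not beyond the scatter. The expected step (a 1.3-fold lower number from compound 2 to compound 3 (0.12 log units; within the scatter)) is therefore small. For compound 3 the estimated value is 220 nM (expected range 70 nM to 700 nM).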

Compound 3, half-maximal inhibitory concentration: 50 nM
Compound 3: the middle estimate sits 4.4-fold (0.64 log units) above what was measured, outside the stated range (below it).
By their numbers in this assay, from the lowest: compounds 3 and 1 (each within the scatter of the next); then compound 2.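

Extending propyl to pentyl, with ethyl in place of hydrogen on a saturated chain carbon, three bonds along the chain from an aromatic carbon, gives a 5.8-fold lower number from compound 2 to compound 3 (0.76 log units; beyond the scatter) in this assay. This shows that chain length at this position matters: this one change, with the rest of the molecule the same, moves the number beyond the scatter. Nothing measured here gives a reason for this step.

On these data alone, whether butyl falls on the way between propyl and pentyl, or whether a longer chain such as heptyl lowers the number further, stays open. So does the effect of a chain ending in an amine or a carboxylic acid at this place.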